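Swapping the Aryl Substituents on the Benzylamide of Compound 3

A few compounds are considered here, and "the series" means these few. Any claim that something is new, unique, unknown or untested is made for them only; others in the source may bear on it.

Three compounds built on a shared core were measured in an assay on microsomes from liver for inhibition of 3-hydroxy-3-methylglutaryl-coenzyme A reductase (Rattus norvegicus); on this read-out lower numbers stand for stronger inhibition and higher numbers for weaker inhibition. Compound 1 `CC(C)c1c(C(=O)N(C)Cc2ccccc2)nn(-c2ccc(F)cc2)c1CC[C@@H](O)C[C@@H](O)CC(=O)O` gives 6.2 nM, compound 2 `CC(C)c1c(C(=O)N2CCC[C@H](c3ccccc3)C2)nn(-c2ccc(F)cc2)c1CC[C@@H](O)C[C@@H](O)CC(=O)O` gives 2.1 nM, and compound 3 `CC(C)c1c(C(=O)NCc2cccc(F)c2F)nn(-c2ccc(F)cc2)c1OC[C@@H](O)C[C@@H](O)CC(=O)O` gives 2 nM. Compound 3 has the lowest of the three numbers; compound 2 stands nearest to it, within the scatter, while compound 1 lies furthest away, beyond the scatter. For the measured compounds named here, the single step among the measured compounds, a 3.0-fold lower number from compound 1 to compound 2 (0.47 log units; beyond the scatter), exchanges the whole amine part of the amide and lies beyond the scatter.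

Compound 4 `Cc1cccc(CNC(=O)c2nn(-c3ccc(F)cc3)c(OC[C@@H](O)C[C@@H](O)CC(=O)O)c2C(C)C)c1` differs from compound 3 only in 3-methylphenyl in place of 2,3-difluorophenyl on a saturated chain carbon bound to an amide-type nitrogen. Going by the values given here, no measured step touches a change of this kind: the one step available replaces the entire amine part of the amide rather than a substituent on a benzyl ring. The account therefore expects no step beyond the scatter in this assay for compound 4. The expected step is a 1.3-fold higher number from compound 3 to compound 4 (0.10 log units; within the scatter). Compound 4 is accordingly estimated to give about 2.5 nM in this assay, within a range from 1 nM to 6.5 nM.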

Compound 4, half-maximal inhibitory concentration: 4.9 nM
Compound 4: middle estimate off by 2.0-fold (0.29 log units), on the low side; the measured number falls inside the stated range.
By their numbers in this assay, from the lowest: compounds 3 and 2 (each within the scatter of the next); then compounds 4 and 1 (each within the scatter of the next).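

In this assay, replacing 2,3-difluorophenyl with 3-methylphenyl on a saturated chain carbon bound to an amide-type nitrogen gives a 2.5-fold higher number from compound 3 to compound 4 (0.39 log units; beyond the scatter) and so lies beyond the scatter. For the compounds shown here, the only earlier step exchanged the whole amine part of the amide, whereas this one shows that the read-out also responds to a change confined to the aryl group on the benzylamide. No measurement shown here addresses the reason for this step.

Both fluorines leave and a methyl enters in this single step, and the compounds shown do not separate the loss of one from the gain of the other. Unsubstituted phenyl, 3-fluorophenyl or 2-fluorophenyl at this place could divide the step into its parts.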